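Hydrogen for trifluoromethoxy on the aryl ring of compound 1

The source may hold more compounds than are shown below. What is called first, only, known or untested is meant among the compounds shown, and "the series" means these compounds.

Compound 1 `CC(c1ccc(-c2ccccc2)c(F)c1)c1nnc2n1N=C(c1ccc(OC(F)(F)F)cc1)CS2` and compound 2 `COc1ccc2cc(C(C)c3nnc4n3N=C(c3ccc(Br)cc3)CS4)ccc2c1` have been measured in a functional assay on Huh-7 cells (Homo sapiens) for inhibition, read by sulforhodamine B assay, with a stated time of 72 h; a lower number here means a stronger inhibitor, a higher number a weaker inhibitor. In this assay compound 1 gives 8400 nM, and compound 2 gives 9300 nM; the two values sit within the scatter of each other, so neither separates from the other. Compound 3 `CC(c1ccc(-c2ccccc2)c(F)c1)c1nnc2n1N=C(c1ccccc1)CS2` awaits measurement. It differs from compound 1 by hydrogen in place of trifluoromethoxy on an aromatic carbon. Among the measured compounds shown here, no measured pair shows this change, so a small weakening or nothing beyond the scatter is expected. Compound 3 is estimated at 12000 nM, within 5000 nM to 30000 nM. The step of a 1.4-fold higher number from compound 1 to compound 3 (0.15 log units; within the scatter) is expected to be modest.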

Compound 3, half-maximal inhibitory concentration: 6700 nM
The estimate for compound 3 lay 1.8-fold (0.25 log units) above the measured number; the range from low to high includes it.
By their numbers in this assay, from the lowest: compounds 3, 1 and 2 (each within the scatter of the next).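

In this assay, the change from 4-(trifluoromethoxy)phenyl to phenyl gives a 1.3-fold lower number from compound 1 to compound 3 (0.10 log units; within the scatter). Among the compounds shown here, this is the first direct reading at this position: removing trifluoromethoxy, with its 5 heavy atoms, leaves the number within the scatter, so the group is not needed to hold this level of inhibition in this pair. No supporting evidence bears on this result. Still open, as far as these compounds go, is whether an amine, a carboxylic acid or a longer alkoxy chain on this aromatic carbon would shift the number beyond the scatter. A single pair also cannot show whether the same change behaves alike with other groups on the rest of the molecule.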